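From compound 2 to compound 3: an aryl exchange

A few compounds are considered here, and "the series" means these few. Any claim that something is new, unique, unknown or untested is made for them only; others in the source may bear on it.

compound 1 `CCOC(=O)C1=C(C)NC(C)=C(C(=O)OCC)C1c1c(-c2ccc(C(F)(F)F)cc2)nc2sccn12` gives 33 nM
compound 2 `C=CCOC(=O)C1=C(C)NC(C)=C(C(=O)OCC=C)C1c1c(-c2ccc(OC(F)(F)F)cc2)nc2sccn12` gives 730 nM

In a functional assay on cardiac atrium (Cavia porcellus) (on this read-out higher numbers stand for an effect only at larger amounts of compound and lower numbers for an effect already at smaller amounts), compound 2 stands at 730 nM as the higher of the two numbers, and compound 1 stands at 33 nM. The gap between the two lies beyond the scatter. Compound 3 `C=CCOC(=O)C1=C(C)NC(C)=C(C(=O)OCC=C)C1c1c(-c2cc(OC)ccc2OC)nc2sccn12` carries 2,5-dimethoxyphenyl in place of 4-(trifluoromethoxy)phenyl on an aromatic carbon and is otherwise the same as compound 2. Among the measured compounds shown here, no single-place step has been measured, so no step beyond the scatter is expected in this assay, and the direction remains open. The expected change is a 1.5-fold lower number from compound 2 to compound 3 (0.16 log units; within the scatter) and stays within the scatter. The estimated value for compound 3 is 500 nM (range 100 nM to 2500 nM) in this series.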

Compound 3, half-maximal effective concentration: 340 nM
Compound 3: the middle estimate sits 1.5-fold (0.17 log units) above what was measured; the measured number falls inside the stated range.
By their numbers in this assay, from the lowest: compound 1; then compound 3; then compound 2.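

At the aromatic carbon on the shared core, 2,5-dimethoxyphenyl in place of 4-(trifluoromethoxy)phenyl gives, in this assay, a 2.1-fold lower number from compound 2 to compound 3 (0.33 log units; beyond the scatter). Among the compounds shown here, this is the first single-place step, and it shows that exchanging the aryl group alone can shift the number beyond the scatter, though the step is modest. From the compounds shown here alone, whether a single methoxy group, an amine or a carboxylic acid on that phenyl ring would shift the number further remains open. Nothing measured on hand accounts for this step.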